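This account rests on a few compounds, and the source may have more. Where it says the series, first, only, none or still open, it means among the compounds named here.

For the measured compounds named here, in a functional assay on HL-60 cells (Homo sapiens) for antiproliferative activity, read by sulforhodamine B assay, with a stated time of 72 h (on this read-out lower numbers stand for stronger inhibition and higher numbers for weaker inhibition), compound 1 `CN(C)C(=S)N/N=C/c1ccc2cccnc2n1` gives 560 nM and so holds the only actual number available so far. Compound 2 `Fc1ccccc1NC(=S)N/N=C/c1ccc2ccccc2n1` shows > 100000 nM as its reading, and that reading is a limit of the assay rather than a number. Compound 2 also differs from compound 1 in more than one place, so comparing them singles out no one group.

Compound 3 `NC(=S)N/N=C/c1ccc2cccnc2n1` keeps the core of compound 1 but carries amino in place of dimethylamino on a thiocarbonyl carbon. Going by the values given here, no measured pair of compounds shows this change on its own, so what follows for this assay is a judgement and not a reading. Starting from compound 1 at 560 nM as the only anchor, a moderate move toward weaker inhibition, beyond the usual scatter, seems the most likely outcome. The expected change is a 4.5-fold higher number from compound 1 to compound 3 (0.65 log units; beyond the scatter) on this estimate. For compound 3 the estimated value is 2500 nM with 500 nM as the expected lower end and 15000 nM as the expected upper end of the range.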

Compound 3, half-maximal inhibitory concentration: > 100000 nM
Compound 3: a limit, no number; the forecaster's own chance of this, stated with the estimate: 5%; middle value at least 40-fold (1.60 log units) from the limit.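

Swapping dimethylamino for amino on a thiocarbonyl carbon gives an at least 170-fold higher number from compound 1 to compound 3 (2.25 log units; beyond the scatter) in this assay, and this is the first comparison here that isolates a single change, which the earlier pair of compounds, differing in more than one place, could not do. The reading of compound 3 is a limit and not a number, so this step marks only the smallest gap the data allow, and its full size cannot be read: the limit of > 100000 nM in this assay, at which 2 of the 3 values shown sit.

Within the compounds shown, then, the activity of compound 1 in this assay does not survive this exchange at this place, although the change is a small one: 3 heavy atoms and no hydrogen-bond donor leave, while 1 heavy atom and 1 hydrogen-bond donor enter.

The compounds shown do not separate these two counted differences, so it stays open which of them goes with the loss. Methylamino, which lies between the two groups, and larger groups such as diethylamino or morpholine would be needed to show whether the reading changes gradually or abruptly at this place.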